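This account rests on a few compounds, and the source may have more. Where it says the series, first, only, none or still open, it means among the compounds named here.

Measured in a functional assay on HeLa cells (Homo sapiens) for cytotoxicity, read by MTT assay, with a stated time of 72 h; a higher number here means a weaker inhibitor, a lower number a stronger inhibitor:
Compound 1 `CCCCCCCCCCCCCCCCOP(=O)([O-])OCCC[N+](C)(C)Cc1ccccc1` gives 62100 nM
Compound 2 `CCCCCCCCCCCCCCCCOP(=O)([O-])OCCC[N+](C)(C)C` gives 84400 nM

For the measured compounds named here, compound 2 stands at 84400 nM, within the scatter of compound 1, the only other compound measured. Compound 3 `CCCCCCCCCCCCCCCCOP(=O)([O-])OCCC[n+]1ccccc1` has not yet been measured. It differs from compound 2 by a group of 6 heavy atoms (5 carbon, 1 nitrogen; one six-membered aromatic ring with 1 hetero atom) in place of a group of 4 heavy atoms (3 carbon, 1 nitrogen; no ring), on a saturated chain carbon, three bonds along the chain from an oxygen. Going by the values given here, the one measured step that bears on this change is a 1.4-fold higher number from compound 1 to compound 2 (0.13 log units; within the scatter), which puts hydrogen in place of phenyl on a saturated chain carbon bound to an amine nitrogen. That step also removes an aromatic ring, but it is a different structural change, so it serves only as a loose guide. Among the compounds with values here, no measured compound carries the six-membered aromatic ring of compound 3. Within the data shown here, with the single available step inside the scatter, no step beyond the scatter is expected in this assay, and neither direction is favoured. This expectation amounts to an estimated 1.2-fold lower number from compound 2 to compound 3 (0.08 log units; within the scatter). The estimated value for compound 3 is 70000 nM, with an expected range from 35000 nM to 130000 nM.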

Compound 3, half-maximal inhibitory concentration: 74700 nM
Compound 3: the middle estimate sits 1.1-fold (0.03 log units) below what was measured, within the range that was stated.
By their numbers in this assay, from the lowest: compounds 1, 3 and 2 (each within the scatter of the next).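

In this assay, for the compounds shown here, the earlier compounds offered no case of a six-membered aromatic ring with 1 hetero atom on the saturated chain carbon, three bonds along the chain from an oxygen. Putting this ring in place of the group of 4 heavy atoms gives a 1.1-fold lower number from compound 2 to compound 3 (0.05 log units; within the scatter), and putting it in place of the group of 10 heavy atoms, which holds a six-membered aromatic ring of carbon only, gives a 1.2-fold higher number from compound 1 to compound 3 (0.08 log units; within the scatter). Neither comparison leaves the scatter, so among the three compounds shown, this place accepts a group with no ring, a ring with 1 hetero atom or a ring of carbon only without a readable change in the number, and no evidence is available to explain this result.

All three groups carry a net charge of +1, so the compounds shown leave open what a carboxylic acid or a primary amine would do at this place. They also leave open whether a shorter chain in the shared core would bring out differences among these groups in this assay.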